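Methyl for Fluoro on a Naphthyl Stilbene-Like Scaffold

The source may report more compounds than this note shows. Statements on the series, on what has been measured and on what is new or still open speak of the compounds shown alone.

Measured so far:
- compound 1 `COc1ccc(C(O)(Cc2ccc(C)cc2)c2cccc3ccccc23)c(OC)c1OC`: > 20000 nM in a functional assay on MCF7 cells (Homo sapiens) for inhibition, read by sulforhodamine B assay, with a stated time of 48 h; on this read-out higher numbers stand for weaker inhibition and lower numbers for stronger inhibition
- compound 2 `COc1ccc(/C(=C\c2ccc(F)cc2)c2cccc3ccccc23)c(OC)c1OC`: 17700 nM
- compound 3 `COc1ccc(/C(=C/c2ccc(F)cc2)c2cccc3ccccc23)c(OC)c1OC`: 10500 nM

The value of compound 1 is a limit of the assay, not a number. Compound 3 holds the lowest of the two numbers available, and its nearest neighbour is compound 2, with the step of a 1.7-fold lower number from compound 2 to compound 3 (0.23 log units; within the scatter). Because (the fact that compounds 2 and 3 differ only in the configuration as drawn), that step speaks only to the drawn geometry of the double bond, and it stays within the scatter.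

Compound 4 `COc1ccc(/C(=C/c2ccc(C)cc2)c2cccc3ccccc23)c(OC)c1OC` carries the change (methyl in place of fluoro on an aromatic carbon). Within the data shown here, no measured step covers this exchange: compound 1 also carries a methyl in the same position, but it differs from compound 4 in more than one place, and its value is only a limit. Among the measured compounds shown here, the only measured step concerns a different change and was small. The expectation for compound 4 is therefore a step of a 1.1-fold higher number from compound 3 to compound 4 (0.06 log units; within the scatter), not clearly beyond the scatter in either direction. Compound 4 is estimated at 12000 nM, with a range from 4000 nM to 35000 nM.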

Compound 4, half-maximal inhibitory concentration: > 20000 nM
Compound 4 ended at the assay's limit; the forecaster's own chance of this, stated with the estimate: 25%; at least 1.6-fold (0.22 log units) between middle value and limit.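

Among these compounds, compound 4 gives the first measured step for fluoro leaving and methyl entering at this place, on an aromatic carbon para to a large group, with the rest of the structure and the drawn geometry of the double bond kept as in compound 3: an at least 1.9-fold higher number from compound 3 to compound 4 (0.27 log units; that floor lies within the scatter). The value of compound 4 is a limit of the assay, not a number, and the step is therefore only a floor, because of one feature of these data: the limit of > 20000 nM in this assay, at which 2 of the 4 values shown sit. Methyl thus brings no sign of stronger inhibition than fluoro on this core, but with the floor inside the scatter, a clear loss is not shown either.

Still open, on these data alone, is how other groups at this place would read out in this assay, such as a hydroxyl, an amine or a carboxylic acid, and whether any of them would give a number clearly lower than that of compound 3. Also open, as far as these compounds go, is how the methyl group would behave with the double bond drawn the other way, as it is in compound 2.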